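A few compounds are considered here, and "the series" means these few. Any claim that something is new, unique, unknown or untested is made for them only; others in the source may bear on it.

Measured compounds:
compound 1 `CN1CCN(CCCOc2cccc3nc(Nc4ccc(Cl)c(C(F)(F)F)c4)ccc23)CC1`: 1620 nM
compound 2 `CN1CCN(CCCOc2cccc3nc(Nc4ccc(F)c(F)c4)ccc23)CC1`: 660 nM
compound 3 `CN1CCN(CCCOc2cccc3nc(Nc4cc(Cl)cc(Cl)c4)ccc23)CC1`: 1660 nM

In a functional assay on K562 cells (Homo sapiens) for inhibition, read by sulforhodamine B assay, with a stated time of 48 h (on this read-out higher numbers stand for weaker inhibition of growth and lower numbers for stronger inhibition of growth), compound 3 gives the highest of the three numbers; it and compound 1 lie within the scatter of each other, a 1.0-fold higher number from compound 1 to compound 3 (0.01 log units; within the scatter), while compound 2 stands apart, a 2.5-fold higher number from compound 2 to compound 3 (0.40 log units; beyond the scatter). Compound 4 `CN1CCN(CCCOc2cccc3nc(Nc4cccc(Cl)c4)ccc23)CC1` carries hydrogen in place of chloro on an aromatic carbon, that is, 3,5-dichlorophenyl to 3-chlorophenyl. Among the measured compounds shown here, no measured step removes a single chloro. For the measured compounds named here, the steps that bear on it exchange the whole aryl group: a 2.5-fold lower number from compound 1 to compound 2 (0.39 log units; beyond the scatter) and a 2.5-fold higher number from compound 2 to compound 3 (0.40 log units; beyond the scatter), both modest and alike in size, with 3,4-difluorophenyl giving the lower number. Compound 4 is therefore expected to show a modest step toward a lower number, a 1.5-fold lower number from compound 3 to compound 4 (0.18 log units; within the scatter), one that may still fall within the scatter. The estimate for compound 4 is 1100 nM, with a range from 400 nM to 3000 nM.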

Compound 4, concentration for 50% growth inhibition: 1790 nM
Compound 4: the middle estimate sits 1.6-fold (0.21 log units) below what was measured, within the range that was stated.
By their numbers in this assay, from the lowest: compound 2; then compounds 1, 3 and 4 (each within the scatter of the next).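

In this assay, hydrogen in place of chloro on this aromatic carbon gives a 1.1-fold higher number from compound 3 to compound 4 (0.03 log units; within the scatter), so the second chloro of the 3,5-dichlorophenyl group makes no difference that can be read here. The 3-chlorophenyl compound also lies within the scatter of the trifluoromethyl-bearing compound, a 1.1-fold higher number from compound 1 to compound 4 (0.04 log units; within the scatter), while a 2.7-fold higher number from compound 2 to compound 4 (0.43 log units; beyond the scatter) leaves the 3,4-difluorophenyl compound alone apart from the other three. Nothing measured here offers an explanation for this.

On these data alone, whether fluoro, methoxy or an amine on this same carbon would move the number remains open. So does whether the remaining chloro can itself be replaced by hydrogen without a readable step.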